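Swapping the pendant aryl ring toward a tetrazolylphenyl group

The source may hold more compounds than are shown below. What is called first, only, known or untested is meant among the compounds shown, and "the series" means these compounds.

Measured compounds:
- compound 1, `CCCS(=O)(=O)Nc1ccc(F)c(C(=O)c2n[nH]c3ncc(-c4ccccc4N)cc23)c1F`, 23%
- compound 2, `CCCS(=O)(=O)Nc1ccc(F)c(C(=O)c2n[nH]c3ncc(-c4ccc(OC)cc4Cl)cc23)c1F`, 5.3%
- compound 3, `CCCS(=O)(=O)Nc1ccc(F)c(C(=O)c2n[nH]c3ncc(-c4cccc([N+](=O)[O-])c4)cc23)c1F`, 15%

In an assay for binding affinity to dual specificity mitogen-activated protein kinase kinase 4 (Homo sapiens), read by KINOMEscan, tested at 100 nM (on this read-out higher numbers stand for a weaker effect at the one concentration tested and lower numbers for a stronger effect), compound 3 gives 15%, the second highest of the three numbers. Its nearest neighbour is compound 1, which gives 23%, and the gap a number 8 percentage points lower from compound 1 to compound 3 (within the scatter) lies within the scatter. Its furthest neighbour is compound 2, which gives 5.3%, yet even the step of a number 9.7 percentage points higher from compound 2 to compound 3 (within the scatter) stays within the scatter. For the measured compounds named here, only the step of a number 17.7 percentage points lower from compound 1 to compound 2 (beyond the scatter) reaches beyond it.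

Compound 4 is `CCCS(=O)(=O)Nc1ccc(F)c(C(=O)c2n[nH]c3ncc(-c4ccc(-c5nnn[nH]5)cc4)cc23)c1F`. It differs from compound 3 as follows: 4-(1H-tetrazol-5-yl)phenyl in place of 3-nitrophenyl on an aromatic carbon. All three measured steps exchange the same pendant aryl group, and two of them stayed within the scatter, so the change in compound 4 is expected to move the number only modestly, with a slight lean toward a lower read-out, the step being estimated at a number 3 percentage points lower from compound 3 to compound 4 (within the scatter). In this assay compound 4 is therefore expected to give about 12%, most likely between 3% and 35%.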

Compound 4, a percentage reported as activity, at one concentration (the size of the read-out at that concentration, not a potency): 0.15%
Beside the measured number, compound 4's estimate is 11.9 percentage points above it; the measured number lies below the stated range.
By their numbers in this assay, from the lowest: compounds 4, 2, 3 and 1 (each within the scatter of the next, the first and the last beyond it).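

In this assay, the change to 4-(1H-tetrazol-5-yl)phenyl gives the first step from compound 3 that passes the scatter, a number 14.9 percentage points lower from compound 3 to compound 4 (beyond the scatter), and the step from the 2-aminophenyl compound is larger still, a number 22.9 percentage points lower from compound 1 to compound 4 (beyond the scatter). Against the 2-chloro-4-methoxyphenyl compound, however, the step stays within the scatter, a number 5.2 percentage points lower from compound 2 to compound 4 (within the scatter), so this position carries a group with a five-membered aromatic ring of 4 hetero atoms on its phenyl ring without the number rising above that of compound 2. Nothing available here accounts for the drop.

The compounds shown leave open whether the tetrazole itself matters or whether another group on the phenyl ring, such as a carboxylic acid or a nitrile, would read the same. With one concentration only, they also leave open how compound 4 and compound 2 compare in potency.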